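Clearance of a para-methoxybenzyl analogue: an estimate

The source may hold more compounds than are shown below. What is called first, only, known or untested is meant among the compounds shown, and "the series" means these compounds.

Measured so far:
compound 1, `O=C(C[C@]1(O)CC[C@@H](Cc2ccccc2)CC1)Nc1ccc2[nH]c(=O)oc2c1`, 34.1 mL/min/kg
compound 2, `O=C(C[C@]1(O)CC[C@@H](Cc2ccc(Cl)cc2)CC1)Nc1ccc2[nH]c(=O)oc2c1`, "not determined" (no result reported)

Compound 1 was tested in an ADME assay on the whole organism (strain Sprague-Dawley) for pharmacokinetics, with Rattus norvegicus as the target, using cassette dosing (a higher number here means faster removal of the compound, a lower number slower removal), and gave 34.1 mL/min/kg. Among the compounds with values here, compound 2, which carries a chloro group on the benzyl ring of the same core, was submitted to this assay, where compound 2 gives "not determined" (no result reported), so compound 2 stands without a number of its own; the only anchor is compound 1.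

Compound 3, `COc1ccc(C[C@H]2CC[C@](O)(CC(=O)Nc3ccc4[nH]c(=O)oc4c3)CC2)cc1`, differs from compound 2 in one place: methoxy in place of chloro on an aromatic carbon. Within the data shown here, since no step between measured compounds is known here, the expectation for this change is a shift no larger than the usual scatter, in no particular direction.

Resting on compound 1, compound 3 is expected to show a clearance in this assay near 38 mL/min/kg, within a range from 18 mL/min/kg to 80 mL/min/kg.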

Compound 3, clearance: 45.9 mL/min/kg
Beside the measured number, compound 3's estimate is 1.2-fold (0.08 log units) below it; low and high end bracket the measured number.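

Compound 3 gives the first readable result for a group on the benzyl ring at the place para to a large group. In this assay, adding methoxy in place of hydrogen gives a 1.3-fold higher number from compound 1 to compound 3 (0.13 log units; within the scatter), so the clearance of these two compounds cannot be told apart, and this place accepts methoxy without a change that stands clear of the scatter. The exchange of chloro for methoxy cannot be read, as compound 2 has no number, and nothing measured here explains the result.

From the compounds shown here alone, it remains open how chloro itself behaves at this place, and whether methoxy would give the same result elsewhere on the ring. Going by these compounds, it is also open whether an amine or a carboxylic acid at this place would shift clearance beyond the scatter.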